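The source may report more compounds than this note shows. Statements on the series, on what has been measured and on what is new or still open speak of the compounds shown alone.

Compound 1 `COc1cc(N(C)CCN(C)C)c(NC(=O)/C=C\C(C)C)cc1Nc1ncc(C#N)c(-c2cn(C)c3ccc(F)cc23)n1` is the reference point of the series. In a functional assay on HepG2 cells (Homo sapiens) for antiproliferative activity, read by MTT assay, with a stated time of 72 h (a lower number here means a stronger inhibitor, a higher number a weaker inhibitor), compound 1 gives 2840 nM. Compound 2 `CCC/C=C\C(=O)Nc1cc(Nc2ncc(C#N)c(-c3cn(C)c4ccc(F)cc34)n2)c(OC)cc1N(C)CCN(C)C` carries the change propyl in place of isopropyl on a double-bonded chain carbon bound to a double-bonded chain carbon on the same core; in this assay compound 2 gives 2010 nM, and the step of a 1.4-fold lower number from compound 1 to compound 2 (0.15 log units; within the scatter) results. Compound 3 `COc1cc(N(C)CCN(C)C)c(NC(=O)/C=C\C(C)C)cc1Nc1nc(C)cc(-c2cn(C)c3ccc(F)cc23)n1` has a different core; the difference between the two cores is not broken down here. In this assay compound 3 gives 14000 nM, the highest of the three measured numbers, with its gap to compound 1 and to compound 2 lying beyond the scatter in both cases. Compound 4 `CCC/C=C\C(=O)Nc1cc(Nc2nc(C)cc(-c3cn(C)c4ccc(F)cc34)n2)c(OC)cc1N(C)CCN(C)C` is not yet measured; it stands to compound 3 as compound 2 stands to compound 1, through (propyl in place of isopropyl on a double-bonded chain carbon bound to a double-bonded chain carbon), at the same place, so this is the same change. Going by the values given here, the expected step of a 1.4-fold lower number from compound 3 to compound 4 (0.15 log units; within the scatter) is small, resting on the single earlier example a 1.4-fold lower number from compound 1 to compound 2 (0.15 log units; within the scatter), which stayed within the scatter. Among the compounds with values here, the core of compound 3 is the only difference from that precedent, so with one prior case the expectation is tentative. Compound 4 is expected to give about 10000 nM in this assay, between 4000 nM and 25000 nM.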

Compound 4, half-maximal inhibitory concentration: 12100 nM
Estimate against measurement, compound 4: 1.2-fold (0.08 log units) below; the measured number falls inside the stated range.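

In this assay, propyl in place of isopropyl on a double-bonded chain carbon bound to a double-bonded chain carbon gives a 1.2-fold lower number from compound 3 to compound 4 (0.06 log units; within the scatter). Set beside the earlier step, the change carries from the core of compound 1 to the core of compound 3 without a difference between the two steps that stands clear of the scatter: the same change on two cores in this assay, a 1.4-fold lower number (0.15 log units; within the scatter) from compound 1 to compound 2 and a 1.2-fold lower number (0.06 log units; within the scatter) from compound 3 to compound 4, 1.2-fold (0.09 log units) apart, within the scatter of two such steps. This supports reading the change as having no resolved effect on these two cores, but it rests on two cases in one assay, says nothing about other cores, and, with neither step beyond the scatter, gives no effect size to carry forward.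

Still open, on these data alone, is whether a different group at this place, such as a longer chain, a cyclopropyl group or a chain ending in an amine, would move the number beyond the scatter. Also open, as far as these compounds go, is how the same change behaves on a core bearing another group, such as a trifluoromethyl group or a carboxylic acid.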